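Amide methylation on a shared core at the solubility limit

The source may hold more compounds than are shown below. What is called first, only, known or untested is meant among the compounds shown, and "the series" means these compounds.

Compound 3 `COc1cncc(-c2cccc(-c3cn4cccc(C(N)=O)c4n3)c2)c1` carries a 5-methoxypyridin-3-yl group on an aromatic carbon of the shared core. In a physicochemical assay for solubility, in phosphate buffer, with a stated time of 24 h, at pH 7.4 (a higher number here means a more soluble compound, a lower number a less soluble compound), compound 3 gives < 1000 nM, which is a limit of the assay and not a number. Compound 1 `NC(=O)c1cccn2cc(-c3cccc(-c4cccc(F)c4)c3)nc12` carries 3-fluorophenyl in that place. In this assay compound 1 gives < 1000 nM, again a limit. Compound 2 `COc1cccc(-c2cccc(-c3cn4cccc(C(N)=O)c4n3)c2)c1` carries 3-methoxyphenyl there. In this assay compound 2 gives < 1000 nM, also a limit. The three steps among these compounds are a step that the two limits leave unreadable from compound 1 to compound 2, a step that the two limits leave unreadable from compound 1 to compound 3 and a step that the two limits leave unreadable from compound 2 to compound 3; all three values sit at the limit of < 1000 nM in this assay, at which 3 of the 3 values shown sit, and no step among them can be read. Compound 4 `COc1cncc(-c2cccc(-c3cn4cccc(C(=O)N(C)C)c4n3)c2)c1` differs from compound 3 by dimethylamino in place of amino on a carbonyl carbon. Among the compounds with values here, none of the measured steps touches the carbamoyl group, and the limits leave no size to compare in any case. The expectation for compound 4 rests only on where compound 3 stands; compound 4 is expected to show a step that the limit leaves unreadable from compound 3 to compound 4 in this assay, no step beyond the scatter. Compound 4 is estimated at 700 nM, within 150 nM to 3000 nM, and is most likely to be reported again only as a limit.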

Compound 4, solubility: 10000 nM
Compound 4: the middle estimate sits 14-fold (1.15 log units) below what was measured; the measured number lies above the stated range.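

Within the data shown here, replacing amino with dimethylamino on the carbonyl carbon gives an at least 10-fold higher number from compound 3 to compound 4 (1.00 log units; beyond the scatter) in this assay, the only step in this set that can be read. The earlier steps all changed the group on an aromatic carbon of the shared core, and none of them can be read: the limit of < 1000 nM in this assay, at which 3 of the 4 values shown sit A change at the carbonyl carbon, carbamoyl to dimethylcarbamoyl, thus gives compound 4 a measured number, so this position can move the read-out beyond the scatter, while a change at the aromatic carbon has shown no readable effect in either direction.

This single pair cannot separate the loss of the amide hydrogen from the addition of the two carbons, and methylamino on the same carbonyl carbon, or a pyrrolidine ring in its place, would bear on that question. From the compounds shown here alone, it also remains open whether dimethylamino would give a step of similar size with 3-fluorophenyl or 3-methoxyphenyl on the aromatic carbon, as it did with 5-methoxypyridin-3-yl there.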